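Nitrile-Bearing Amine on the Shared Core

The source may report more compounds than this note shows. Statements on the series, on what has been measured and on what is new or still open speak of the compounds shown alone.

Compound 2 `CCCN(CC1CC1)c1nc(C)nc2c(-c3ccc(OC)cc3C)c(C)nn12` sits at the strong end of the two numbers in hand: in an assay on cell membranes for displacement of a labelled ligand from corticotropin-releasing factor receptor 1 (Rattus norvegicus) (a higher number here means a weaker inhibitor, a lower number a stronger inhibitor), compound 2 gives 1.96 nM. Among the measured compounds shown here, its only neighbour, compound 1 `COc1ccc(-c2c(C)nn3c(NC4CCC4)nc(C)nc23)c(C)c1`, gives 24.6 nM in this assay, and the one single-point step measured so far, a 13-fold lower number from compound 1 to compound 2 (1.10 log units; beyond the scatter), comes from exchanging cyclobutylamino for (cyclopropylmethyl)(propyl)amino at the same position on the shared core. The unmeasured compound 3 `COc1ccc(-c2c(C)nn3c(N(CCC#N)C4CC4)nc(C)nc23)c(C)c1` keeps a tertiary amine there but alters both of its arms: (2-cyanoethyl)(cyclopropyl)amino in place of (cyclopropylmethyl)(propyl)amino on an aromatic carbon. The earlier step shows that this amine position can move the number a great deal, yet it concerns a different exchange, a secondary amine for a tertiary one, and nothing measured speaks to a 2-cyanoethyl chain in place of propyl or to cyclopropyl in place of cyclopropylmethyl. With both amines tertiary and alike in size, the expected step of a 1.8-fold higher number from compound 2 to compound 3 (0.25 log units; within the scatter) is modest and could run either way, most likely a slight weakening. Compound 3 is therefore estimated at 3.5 nM, with a plausible range from 0.9 nM to 14 nM.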

Compound 3, half-maximal inhibitory concentration: 1.88 nM
Beside the measured number, compound 3's estimate is 1.9-fold (0.27 log units) above it, and the stated range covers the measured number.
By their numbers in this assay, from the lowest: compounds 3 and 2 (each within the scatter of the next); then compound 1.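

In this assay, placing (2-cyanoethyl)(cyclopropyl)amino where (cyclopropylmethyl)(propyl)amino stood gives a 1.0-fold lower number from compound 2 to compound 3 (0.02 log units; within the scatter), so a chain ending in a nitrile, which brings a second hydrogen-bond acceptor into the group, leaves the two compounds indistinguishable in this assay. The comparison with the secondary amine gives a 13-fold lower number from compound 1 to compound 3 (1.12 log units; beyond the scatter), so two different tertiary amines, in compound 2 and compound 3, now both stand well clear of cyclobutylamino, although three compounds are too few to make this a general rule. Nothing shown here accounts for the match between the two tertiary amines.

Both arms of the amine differ between compound 2 and compound 3, so the contribution of the 2-cyanoethyl chain cannot be separated from that of cyclopropyl replacing cyclopropylmethyl, and the two could be offsetting each other or could each matter little. On these data alone, it also remains open how this position would respond to a 2-hydroxyethyl chain, a chain ending in a carboxylic acid, or a longer 3-cyanopropyl chain.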